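Methoxy in place of chloro on the shared core

This account rests on a few compounds, and the source may have more. Where it says the series, first, only, none or still open, it means among the compounds named here.

Compound 1 `COc1ccc2[nH]c(-c3cn(-c4ccccc4)nc3-c3ccc(F)cc3)nc2c1` gives 7510 nM
Compound 2 `Clc1ccc(-c2nn(-c3ccccc3)cc2-c2nc3cc(Cl)ccc3[nH]2)cc1` gives 1630 nM

Both numbers come from a functional assay on HeLa cells (Homo sapiens) for antiproliferative activity, read by MTT assay, with a stated time of 48 h (a higher number here means a weaker inhibitor, a lower number a stronger inhibitor), and compound 2 (1630 nM) is the stronger inhibitor of the two, by a gap beyond the usual scatter. Compound 3 `COc1ccc2[nH]c(-c3cn(-c4ccccc4)nc3-c3ccc(Cl)cc3)nc2c1` is compound 2 with a single change: methoxy in place of chloro on an aromatic carbon. Within the data shown here, no measured pair shows this change on its own, so its size can only be estimated. Compound 1 also carries a methoxy group and reads 7510 nM, which suggests weaker inhibition, although this one value leaves the estimate wide. A moderate rise in the number is expected, a 2.3-fold higher number from compound 2 to compound 3 (0.37 log units; beyond the scatter). For compound 3 the estimated value is 3800 nM, with an expected range from 1500 nM to 9500 nM.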

Compound 3, half-maximal inhibitory concentration: 3630 nM
Compound 3: the middle estimate sits 1.0-fold (0.02 log units) above what was measured; low and high end bracket the measured number.
By their numbers in this assay, from the lowest: compound 2; then compound 3; then compound 1.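

In this assay, among these compounds, methoxy in place of chloro on the fused system of two rings gives a 2.2-fold higher number from compound 2 to compound 3 (0.35 log units; beyond the scatter) and so puts a direct measure on this change for the first time: at this carbon of the shared core, the chloro compound is the stronger inhibitor. The second pair isolates a different place, where chloro in place of fluoro on an aromatic carbon gives a 2.1-fold lower number from compound 1 to compound 3 (0.32 log units; beyond the scatter) and chloro again goes with the lower number, a pattern that rests on these three compounds alone. Nothing available explains why either change moves the number.

As far as these compounds go, how an amine or a carboxylic acid would read on the carbon that carries chloro or methoxy remains open. So does whether a longer chain in place of methoxy would raise the number further.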